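A few compounds are considered here, and "the series" means these few. Any claim that something is new, unique, unknown or untested is made for them only; others in the source may bear on it.

Working notes on the series.

Two cores are represented. Compound 1 `COc1ccc(NC(=S)Nn2c(S)nnc2-c2ccncc2)cc1` and compound 2 `Cc1ccc(NC(=S)Nn2c(S)nnc2-c2ccncc2)cc1` share the first core. In a functional assay on NUGC cells (Homo sapiens) for cytotoxicity, read by sulforhodamine B assay, with a stated time of 24 h (a lower number here means a stronger inhibitor, a higher number a weaker inhibitor), compound 1 gives 1820 nM, and compound 2 gives 2770 nM. The change between them is methyl in place of methoxy on an aromatic carbon and it made a 1.5-fold higher number from compound 1 to compound 2 (0.18 log units; within the scatter).

For the measured compounds named here, compound 3 `COc1ccc(Nc2nn3c(-c4ccncc4)nnc3s2)cc1` carries the second core and is the only member of that core measured so far; in this assay compound 3 gives 56 nM, the lowest number of the three, and its gaps to compound 1 and compound 2 both lie beyond the scatter. The difference between the two cores is not broken down here.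

Compound 4 `Cc1ccc(Nc2nn3c(-c4ccncc4)nnc3s2)cc1` is not yet measured. It differs from compound 3 by methyl in place of methoxy on an aromatic carbon, the same change as that from compound 1 to compound 2, at the same place. Since that earlier step stayed within the scatter, the step from compound 3 to compound 4 in this assay is expected to be small as well, estimated as a 1.5-fold higher number from compound 3 to compound 4 (0.18 log units; within the scatter), resting on a 1.5-fold higher number from compound 1 to compound 2 (0.18 log units; within the scatter). Compound 4 is accordingly estimated at 85 nM, with a likely range from 35 nM to 220 nM.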

Compound 4, half-maximal inhibitory concentration: 540 nM
Estimate against measurement, compound 4: 6.4-fold (0.80 log units) below, and the stated range ends below it.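

In this assay methyl in place of methoxy on an aromatic carbon gives a 9.6-fold higher number from compound 3 to compound 4 (0.98 log units; beyond the scatter) and this step lies beyond the scatter, so the change is not neutral on the core of compound 3. The size of the step therefore does not carry from one core to the other in this series: the same change on two cores in this assay, a 1.5-fold higher number (0.18 log units; within the scatter) from compound 1 to compound 2 and a 9.6-fold higher number (0.98 log units; beyond the scatter) from compound 3 to compound 4, 6.3-fold (0.80 log units) apart, beyond the scatter of two such steps. For the compounds shown here, this rests on a single pair on each core in one assay, so it shows only that the step differs between these two cores; it does not show why they differ, nor what the same change would do on any further core.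

The comparison at this place covers only methoxy and methyl, which leaves open whether the large step on the core of compound 3 is specific to this pair of groups. As far as these compounds go, how an amine, a hydroxyl or a longer chain such as ethoxy at the same place would read on each core in this assay also remains open.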